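Two Selenoether Pyrimidines and an Amino Analogue

The source may report more compounds than this note shows. Statements on the series, on what has been measured and on what is new or still open speak of the compounds shown alone.

Measured compounds:
Compound 1, `CCCCC[Se]c1nc([Se]CCCCC)c2cccnc2n1` — 40800 nM
Compound 2, `CCCCC[Se]c1nc([Se]CCCCC)c2ccccc2n1` — 38400 nM

In a functional assay on MCF7 cells (Homo sapiens) for cytotoxicity, read by MTT assay, with a stated time of 72 h (a higher number here means a weaker inhibitor of growth, a lower number a stronger inhibitor of growth), compound 1 gives 40800 nM. Compound 2, which carries the same two pentylselanyl groups on a different fused core, gives 38400 nM in this assay. These two numbers lie within the usual scatter of each other, so nothing separates compound 1 from compound 2 in this assay; both are weak inhibitors of growth, and compound 1 is simply one of two measured compounds with a number in this range.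

Compound 3, `CCCCC[Se]c1nc(N)c2cccnc2n1`, has not yet been measured. It differs from compound 1 in one place: one nitrogen atom in place of a group of 6 heavy atoms (5 carbon, 1 selenium; no ring), on an aromatic carbon. Within the data shown here, no measured pair in this set shows the effect of such a change, so there is no step to lean on.

Given that compound 1 gives 40800 nM in this assay, compound 3 is expected to stay in the same weak range, with a step from compound 1 to compound 3 of a 1.5-fold higher number from compound 1 to compound 3 (0.17 log units; within the scatter), which may well not rise beyond the scatter. The estimate for compound 3 in this assay is 60000 nM, with a range from 20000 nM to 200000 nM.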

Compound 3, concentration for 50% growth inhibition: 22700 nM
The estimate for compound 3 lay 2.6-fold (0.42 log units) above the measured number; the range from low to high includes it.
By their numbers in this assay, from the lowest: compounds 3, 2 and 1 (each within the scatter of the next).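

In this assay, among these compounds, exchanging a pentylselanyl group on this aromatic carbon for amino gives a 1.8-fold lower number from compound 1 to compound 3 (0.25 log units; within the scatter), the first step in the set between two compounds that differ in one place. The step does not rise beyond the scatter, so at this position, opposite the ring nitrogen, a single amino group stands in for a group of 6 heavy atoms without any change that can be told apart in this assay, and compound 3 remains in the same weak range as compound 1. Nothing available explains this outcome at this position.

Still open, going by these compounds, is whether a different group on this carbon, such as a dimethylamino group, a morpholine ring or a shorter chain like methylselanyl, would move the number beyond the scatter. Also open, on these data alone, is what the remaining pentylselanyl group of compound 3 contributes, whether as a longer chain or when exchanged for a second amine, and whether the same amino exchange would behave alike on the core of compound 2.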